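Notes on the amide aryl group, compound 1 to compound 4

A few compounds are considered here, and "the series" means these few. Any claim that something is new, unique, unknown or untested is made for them only; others in the source may bear on it.

Measured so far:
Compound 1 `O=C(CCCCCCNC(=O)C(O)(O)C(F)(F)F)Nc1nc2ccccc2s1`: 2370 nM
Compound 2 `COc1ccc2sc(NC(=O)CCCCCCNC(=O)C(O)(O)C(F)(F)F)nc2c1`: 2180 nM
Compound 3 `O=C(CCCCCCNC(=O)C(O)(O)C(F)(F)F)Nc1nc2ccc(Cl)cc2s1`: 11000 nM

All three numbers come from a functional assay on HCT-116 cells (Homo sapiens) for inhibition, read by colorimetric assay, with a stated time of 3 days; a lower number here means a stronger inhibitor, a higher number a weaker inhibitor. Compound 1 sits second highest of the three: compound 2 is nearest, with a 1.1-fold lower number from compound 1 to compound 2 (0.04 log units; within the scatter), while compound 3 is furthest, with a 4.6-fold higher number from compound 1 to compound 3 (0.67 log units; beyond the scatter).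

Compound 4 `COc1cccc(NC(=O)CCCCCCNC(=O)C(O)(O)C(F)(F)F)c1` differs from compound 1 by 3-methoxyphenyl in place of 1,3-benzothiazol-2-yl on an amide-type nitrogen. Among the measured compounds shown here, neither measured step bears directly on this change; both alter a substituent on the core of compound 1 rather than exchanging the aryl group itself, and the one step beyond the scatter weakened compound 3. The exchange is therefore judged with little support, and a modest weakening is expected, a 2.1-fold higher number from compound 1 to compound 4 (0.32 log units; beyond the scatter). Compound 4 is estimated at 5000 nM, in the range 1500 nM to 20000 nM.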

Compound 4, half-maximal inhibitory concentration: 6110 nM
Compound 4: middle estimate off by 1.2-fold (0.09 log units), on the low side; low and high end bracket the measured number.
By their numbers in this assay, from the lowest: compounds 2 and 1 (each within the scatter of the next); then compounds 4 and 3 (each within the scatter of the next).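

In this assay, the aryl group on the amide-type nitrogen can be exchanged outright: 3-methoxyphenyl in place of 1,3-benzothiazol-2-yl gives a 2.6-fold higher number from compound 1 to compound 4 (0.41 log units; beyond the scatter) and is a weakening step. Inhibition therefore persists without the five-membered aromatic ring, at a modest cost. No measurement at hand explains this weakening.

The compounds shown leave open whether an unsubstituted phenyl or a pyridyl group on this nitrogen would recover the number of compound 1. They also leave open how an amine on the 3-methoxyphenyl ring would act.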